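The source may hold more compounds than are shown below. What is called first, only, known or untested is meant among the compounds shown, and "the series" means these compounds.

Measured compounds in an assay on isolated protein for agonist activity at melatonin receptor type 1C (Xenopus laevis), read by spectrophotometry; a higher number here means that more compound is needed for the effect, a lower number that less compound is needed:

compound 1 `CCC(=O)NCc1cc(OC)ccc1F`: 2400 nM
compound 2 `CCCC(=O)NCc1cc(OC)ccc1F`: 1350 nM
compound 3 `CCC(=O)NCCCc1ccc(F)c(OC)c1`: 1.1 nM

Compound 3 gives the lowest number of the three, and its gaps to compound 2 and compound 1 lie beyond the scatter. The difference between the core of compound 1 and the core of compound 3 is not broken down here. From compound 1 to compound 2 the change is methyl in place of hydrogen on a saturated chain carbon, two bonds along the chain from a carbonyl carbon, and it gave a 1.8-fold lower number from compound 1 to compound 2 (0.25 log units; within the scatter).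

Compound 4 `CCCC(=O)NCCCc1ccc(F)c(OC)c1` is to be measured in this assay. It differs from compound 3 by methyl in place of hydrogen on a saturated chain carbon, two bonds along the chain from a carbonyl carbon, the same change at the same place as before. Because the earlier step gave a 1.8-fold lower number from compound 1 to compound 2 (0.25 log units; within the scatter), the step expected here is a 1.4-fold lower number from compound 3 to compound 4 (0.14 log units; within the scatter). Compound 4 is expected at 0.8 nM, within a range from 0.3 nM to 2.5 nM.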

Compound 4, half-maximal effective concentration: 0.891 nM
For compound 4 the middle estimate is 1.1-fold (0.05 log units) below the measured one; measured number inside the range.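

In this assay the methyl in place of hydrogen on a saturated chain carbon, two bonds along the chain from a carbonyl carbon, gives a 1.2-fold lower number from compound 3 to compound 4 (0.09 log units; within the scatter) and so leaves propanoyl and propylcarbonyl indistinguishable on the core of compound 3. Set beside the same change on the core of compound 1, the two steps agree: the same change on two cores in this assay, a 1.8-fold lower number (0.25 log units; within the scatter) from compound 1 to compound 2 and a 1.2-fold lower number (0.09 log units; within the scatter) from compound 3 to compound 4, 1.4-fold (0.16 log units) apart, within the scatter of two such steps. The change therefore carries between these two cores without a step beyond the scatter on either, but this does not establish a real effect of the methyl, and two cores do not make a rule for the series.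

Still open, on these data alone, is whether a longer chain in the same place would behave alike on both cores. An amine or a carboxylic acid at the end of that chain also remains untested in the compounds shown here.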